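A few compounds are considered here, and "the series" means these few. Any claim that something is new, unique, unknown or untested is made for them only; others in the source may bear on it.

Compound 1 `O=C(/C(=C\c1ccc(Br)cc1)Sc1ccc(Br)cc1)c1ccc(Br)cc1` gives 1000 nM in a functional assay on DU-145 cells (Homo sapiens) for inhibition, read by trypan blue exclusion, with a stated time of 96 h; a higher number here means a weaker inhibitor of growth, a lower number a stronger inhibitor of growth. Compound 2 `COc1ccc(S/C(=C/c2ccc(Br)cc2)C(=O)c2ccc(Br)cc2)cc1` gives 20000 nM in this assay. Compound 3 `O=C(/C(=C\c1ccccc1OCc1ccccc1)S(=O)(=O)c1ccc(Br)cc1)c1ccc(Cl)cc1` gives 1000 nM in this assay.

Between compound 1 and compound 2 the change is methoxy in place of bromo on an aromatic carbon and it brought a 20-fold higher number from compound 1 to compound 2 (1.30 log units; beyond the scatter). Compound 4 `COc1ccc(S(=O)(=O)/C(=C/c2ccccc2OCc2ccccc2)C(=O)c2ccc(Cl)cc2)cc1` carries the same change on the core of compound 3, namely (methoxy in place of bromo on an aromatic carbon); the difference between the cores of compound 1 and compound 3 is not broken down here. Since the step is the same change at the same kind of place, a step of similar direction is expected for compound 4, although the two cores differ and the size may not carry over fully. The expected step from compound 3 to compound 4 is a 12-fold higher number from compound 3 to compound 4 (1.08 log units; beyond the scatter), resting on a 20-fold higher number from compound 1 to compound 2 (1.30 log units; beyond the scatter). Compound 4 is therefore estimated at 12000 nM, between 2500 nM and 50000 nM.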

Compound 4, concentration for 50% growth inhibition: 1000 nM
Beside the measured number, compound 4's estimate is 12-fold (1.08 log units) above it, outside the stated range (below it).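

In this assay, methoxy in place of bromo gave no change at the digits printed from compound 3 to compound 4 (within the scatter). The same swap therefore does not behave alike on the two cores: the same change on two cores in this assay, a 20-fold higher number (1.30 log units; beyond the scatter) from compound 1 to compound 2 and no change at the digits printed (within the scatter) from compound 3 to compound 4, 20-fold (1.30 log units) apart, beyond the scatter of two such steps

This shows that the large step seen on the core of compound 1 cannot simply be carried over to the core of compound 3, but it does not show which part of the cores makes the difference, and two pairs of compounds set no rule for the series.

The compounds shown leave open which feature of the core decides whether this swap matters. They also leave open how other groups at the same place on the ring, such as an amine or a carboxylic acid, would behave on each core.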